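The compounds below may be only part of what the source reports. "The series", "measured", "known", "first", "only" and "open" are said of these compounds alone.

Among the measured compounds shown here, in a functional assay on MDA-MB-231 cells (Homo sapiens) for antiproliferative activity, read by sulforhodamine B assay, with a stated time of 72 h (on this read-out lower numbers stand for stronger inhibition and higher numbers for weaker inhibition), compound 1 (`Cc1ccc(S(=O)(=O)Nc2cc(SCC(=O)N[C@@H](CC(C)C)B(O)O)c(O)c3ccccc23)cc1`) gives 14000 nM as the higher of the two numbers measured so far. Compound 2 (`CC(C)C[C@H](NC(=O)CSc1cc(NS(=O)(=O)c2cccs2)c2ccccc2c1O)B(O)O`) gives 6520 nM on the same read-out. For the measured compounds named here, the only measured step is a 2.1-fold lower number from compound 1 to compound 2 (0.33 log units; beyond the scatter) and it is modest, with thiophen-2-yl in place of 4-methylphenyl on a sulfonyl sulfur.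

Compound 3 (`Cc1ccc(S(=O)(=O)Nc2cc(SCCC(=O)N[C@@H](CC(C)C)B(O)O)c(O)c3ccccc23)cc1`) keeps the 4-methylphenyl of compound 1 and differs elsewhere. The difference is a group of 12 heavy atoms (7 carbon, 1 boron, 1 nitrogen, 3 oxygen; no ring) in place of a group of 11 heavy atoms (6 carbon, 1 boron, 1 nitrogen, 3 oxygen; no ring), on a saturated chain carbon bound to a sulfur and it lies on a saturated chain carbon bound to a sulfur. Going by the values given here, no measured step touches that place, so the data show no direction for this change. The step to compound 2 serves only as a rough gauge of size, and it stands at a 2.1-fold lower number from compound 1 to compound 2 (0.33 log units; beyond the scatter) in a different part of the structure. A small step, possibly none beyond the scatter, is therefore expected in this assay with neither direction clearly favoured. The expected step is a 1.2-fold lower number from compound 1 to compound 3 (0.07 log units; within the scatter) on this estimate. Compound 3 is estimated at 12000 nM with an expected range from 5000 nM to 28000 nM in this assay.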

Compound 3, half-maximal inhibitory concentration: 6150 nM
For compound 3 the middle estimate is 2.0-fold (0.29 log units) above the measured one; low and high end bracket the measured number.
By their numbers in this assay, from the lowest: compounds 3 and 2 (each within the scatter of the next); then compound 1.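

In this assay the place on a saturated chain carbon bound to a sulfur now has a measured direction: the group of 12 heavy atoms in place of the group of 11 heavy atoms gives a 2.3-fold lower number from compound 1 to compound 3 (0.36 log units; beyond the scatter) with the 4-methylphenyl of compound 1 kept unchanged. Up to this point the only step that could be read lay on a sulfonyl sulfur, so this is the first sign that the number also responds to a change in a second part of the structure, and that a small change in heavy-atom count there can move it beyond the scatter. Nothing at hand accounts for this step.

The compounds shown leave open whether a longer chain at this place would continue in the same direction or reverse it, and whether an amine or an ether oxygen within the chain would keep the step. They also leave open how thiophen-2-yl on the sulfonyl sulfur and the group of 12 heavy atoms on the saturated chain carbon would behave when they stand together in one compound.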